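The source may hold more compounds than are shown below. What is called first, only, known or untested is meant among the compounds shown, and "the series" means these compounds.

Three compounds share one core and differ only in the chain on the oxygen of the aromatic ring. Compound 1 `CCCCOc1ccccc1Cc1cnc(N)nc1N` gives 8710 nM in an assay for inhibition of Dihydrofolate reductase (Gallus gallus); on this read-out higher numbers stand for weaker inhibition and lower numbers for stronger inhibition. Compound 2 `C=CCOc1ccccc1Cc1cnc(N)nc1N` gives 21400 nM in this assay, and compound 3 `CCOc1ccccc1Cc1cnc(N)nc1N` gives 24500 nM. Compound 3 shows the highest number of the three, though the step of a 1.1-fold higher number from compound 2 to compound 3 (0.06 log units; within the scatter) is within the scatter, while the step of a 2.8-fold higher number from compound 1 to compound 3 (0.45 log units; beyond the scatter) is beyond it.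

Compound 4 `NC(=O)COc1ccccc1Cc1cnc(N)nc1N` has not yet been measured in this assay. It differs from compound 3 by carbamoyl in place of methyl on a saturated chain carbon bound to an oxygen on an aromatic ring. Going by the values given here, two measured steps bear on this change. The step of a 2.8-fold higher number from compound 1 to compound 3 (0.45 log units; beyond the scatter) shows that cutting the chain short raised the number modestly, and the step of a 1.1-fold higher number from compound 2 to compound 3 (0.06 log units; within the scatter) shows that swapping vinyl for methyl on the same carbon changed little. Among the compounds with values here, the change toward compound 4 lengthens the chain again, so a modest fall in the number is expected, a 1.6-fold lower number from compound 3 to compound 4 (0.21 log units; within the scatter), although no measured compound carries a group of this kind. For compound 4 the estimate is 15000 nM, with a range from 5000 nM to 45000 nM.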

Compound 4, inhibition constant: 33900 nM
Beside the measured number, compound 4's estimate is 2.3-fold (0.35 log units) below it; low and high end bracket the measured number.
By their numbers in this assay, from the lowest: compound 1; then compounds 2, 3 and 4 (each within the scatter of the next).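

In this assay, carbamoyl on the saturated chain carbon bound to the oxygen gives a result that cannot be told apart from those with methyl or vinyl there: a 1.4-fold higher number from compound 3 to compound 4 (0.14 log units; within the scatter) and a 1.6-fold higher number from compound 2 to compound 4 (0.20 log units; within the scatter) are both within the scatter. Against propyl the gap is beyond the scatter, a 3.9-fold higher number from compound 1 to compound 4 (0.59 log units; beyond the scatter), so compound 1 now stands apart from all three others, and a carbamoyl group, with its added nitrogen and oxygen, does not match what propyl gives at this place. Nothing available explains why these compounds fall as they do.

On these data alone, whether an amine or a carboxylic acid on this carbon would fall with compound 1 or with the other three stays open. So does whether a longer chain than the one in compound 1 would give a still lower number.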